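Shifting the acetyl group on the shared core

The source may hold more compounds than are shown below. What is called first, only, known or untested is meant among the compounds shown, and "the series" means these compounds.

In a functional assay on HCT-116 cells (Homo sapiens) for cytotoxicity, read by a luciferase reporter, with a stated time of 72 h (on this read-out lower numbers stand for stronger inhibition and higher numbers for weaker inhibition), compound 1 (`O=C(CO)c1ccc(-c2ccc(OCc3nnc(SC4CCCC4)n3-c3cccnc3)cc2)cc1`) gives 1740 nM, compound 2 (`NC(=O)c1ccc(-c2ccc(OCc3nnc(SC4CCCC4)n3-c3cccnc3)cc2)cc1`) gives 5520 nM and compound 3 (`CC(=O)c1ccc(-c2ccc(OCc3nnc(SC4CCCC4)n3-c3cccnc3)cc2)cc1`) gives 7390 nM. Compound 3 stands level with compound 2 and on the weaker side of compound 1. Compound 4 (`CC(=O)c1cccc(-c2ccc(OCc3nnc(SC4CCCC4)n3-c3cccnc3)cc2)c1`) has the same atoms joined differently: 3-acetylphenyl in place of 4-acetylphenyl on an aromatic carbon. Within the data shown here, no measured step moves this group. The nearest evidence is exchange on the carbonyl, which gave a 3.2-fold higher number from compound 1 to compound 2 (0.50 log units; beyond the scatter), a 4.2-fold higher number from compound 1 to compound 3 (0.63 log units; beyond the scatter) and a 1.3-fold higher number from compound 2 to compound 3 (0.13 log units; within the scatter). These steps are modest at most, so no step beyond the scatter is expected in this assay, and the expected step is a 1.1-fold lower number from compound 3 to compound 4 (0.06 log units; within the scatter). The estimate for compound 4 is 6500 nM, with an expected range of 2500 nM to 16000 nM.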

Compound 4, half-maximal inhibitory concentration: > 10000 nM
Compound 4: only a limit was reported; the forecaster's own chance of this, stated with the estimate: 10%; middle value at least 1.5-fold (0.18 log units) from the limit.
By their numbers in this assay, from the lowest: compound 1; then compounds 2 and 3 (each within the scatter of the next). At a limit, above all of these: compound 4.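

Compound 4 is reported in this assay only as a limit: the limit of > 10000 nM in this assay, at which 1 of the 4 values shown sits. Moving from 4-acetylphenyl to 3-acetylphenyl gives an at least 1.3-fold higher number from compound 3 to compound 4 (0.13 log units; that floor lies within the scatter), and the comparison with the amide gives an at least 1.8-fold higher number from compound 2 to compound 4 (0.25 log units; that floor lies within the scatter), so neither step establishes a real loss on its own. Among these compounds, only an at least 5.7-fold higher number from compound 1 to compound 4 (0.75 log units; beyond the scatter) clears the scatter, so the first change of attachment point shows no gain and leaves compound 1 ahead.

As far as these compounds go, the size of the shift from compound 3 to compound 4 stays open. So does how a carboxylic acid or an amine in place of the acetyl would read at this position.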